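The source may report more compounds than this note shows. Statements on the series, on what has been measured and on what is new or still open speak of the compounds shown alone.

In a functional assay on MCF7 cells (Homo sapiens) for cytotoxicity, read by MTT assay, with a stated time of 72 h (on this read-out lower numbers stand for stronger inhibition and higher numbers for weaker inhibition), compound 1 (`O=C(N/N=C/c1ccc(O)cc1O)Nc1cc2c(Nc3ccc(F)c(Cl)c3)ncnc2cc1O[C@H]1CCOC1`) gives 5350 nM while compound 2 (`COc1cc2ncnc(Nc3ccc(F)c(Cl)c3)c2cc1NC(=O)N/N=C/c1ccc(OC)c(OC)c1OC`) is recorded as "not active" (no number reported) and so has no number on this scale. Compound 3 (`COc1cc2ncnc(Nc3ccc(F)c(Cl)c3)c2cc1NC(=O)N/N=C/c1ccc(O)cc1O`) has yet to be measured. The structural change is 2,4-dihydroxyphenyl in place of 2,3,4-trimethoxyphenyl on a carbon with a double bond to nitrogen on a carbon with a double bond to nitrogen, with 2,4-dihydroxyphenyl in place of 2,3,4-trimethoxyphenyl. Compound 1 also carries 2,4-dihydroxyphenyl and gives 5350 nM in this assay so a step toward stronger inhibition is expected, from no number to a measurable value of similar size. For compound 3 the expected value is 8000 nM with an estimated range from 3000 nM to 25000 nM in this test.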

Compound 3, half-maximal inhibitory concentration: 36200 nM
Estimate against measurement, compound 3: 4.5-fold (0.66 log units) below, outside the stated range (above it).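

In this assay compound 3, carrying 2,4-dihydroxyphenyl, gives 36200 nM while compound 2, carrying 2,3,4-trimethoxyphenyl, has no number, so the size of that change cannot be read. With 2,4-dihydroxyphenyl held constant, methyl in place of oxolan-3-yl on an oxygen on an aromatic ring gives a 6.8-fold higher number from compound 1 to compound 3 (0.83 log units; beyond the scatter), showing that the value also depends on the group on that oxygen. No evidence is available to explain either result.

As far as these compounds go, whether an amine or a longer chain on that oxygen would give a value closer to compound 1 or to compound 3 remains open. Also open, from the compounds shown here alone, is how a carboxylic acid in place of 2,4-dihydroxyphenyl would read.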